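The source may report more compounds than this note shows. Statements on the series, on what has been measured and on what is new or still open speak of the compounds shown alone.

In a functional assay on NCI-H460 cells (Homo sapiens) for inhibition, read by sulforhodamine B assay, with a stated time of 48 h (a lower number here means a stronger inhibitor of growth, a higher number a weaker inhibitor of growth), compound 1 `COc1cc(OC)c(OC)cc1/C=C/C1CC=CC(=O)O1` gives 9.8 uM. Compound 2 `COc1ccc(/C=C/C2CC=CC(=O)N2)cc1OC` does not give a number in this assay but only a limit of the assay, > 964 uM. On the two numbers shown, compound 2 thus stands at the weak end, and it is the single compound sitting at the limit of > 964 uM in this assay, at which 1 of the 2 values shown sits. Compound 3 `COc1cc(OC)c(OC)cc1/C=C/C1CC=CC(=O)N1` differs from compound 2 by methoxy in place of hydrogen on an aromatic carbon. Among the compounds with values here, no measured step joins compound 2 to compound 3, and none joins compound 1 to compound 3 either; the structures show only that compound 1 carries the same aromatic substitution as compound 3 on a different core, while compound 2 shares the core of compound 3. With compound 2 at a limit, the size of any step in this assay cannot be read from the data. The step from compound 2 to compound 3 is expected to run modestly toward stronger inhibition of growth, estimated as an at least 4.8-fold lower number from compound 2 to compound 3 (0.68 log units; beyond the scatter). Compound 3 is estimated at 200 uM, with a range from 30 uM to 964 uM.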

Compound 3, concentration for growth inhibition (reported as GI): > 864 uM
Compound 3 ended at the assay's limit; the forecaster's own chance of this, stated with the estimate: 45%; middle value at least 4.3-fold (0.63 log units) from the limit.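

In this assay compound 3 gives only a limit of the assay, > 864 uM. Within the data shown here, the one readable step concerns the core, with the aromatic substitution unchanged: an at least 88-fold higher number from compound 1 to compound 3 (1.94 log units; beyond the scatter), so exchanging the core of compound 1 for that of compound 3 costs a large part of the growth inhibition. Methoxy in place of hydrogen on an aromatic carbon leaves the core shared by compound 2 and compound 3 without a measured number, and the step between them cannot be read, because both ends are limits: the limit of > 864 uM in this assay, at which 1 of the 3 values shown sits.

The compounds shown leave open whether this methoxy has any effect on the core of compound 1, as that core appears here with only one aromatic substitution. They also leave open whether a different group in that place, such as a hydroxyl or an amine, or a methyl on the ring nitrogen of the core of compound 3, would give a measurable number in this assay.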